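Configuration changes and the half-life of compound 4

The source may report more compounds than this note shows. Statements on the series, on what has been measured and on what is new or still open speak of the compounds shown alone.

In an ADME assay on Colon (Mus musculus, strain C57BL/6) for metabolic stability, read by HPLC, with a stated time of 12 h (a lower number here means that the compound disappears faster, a higher number that the compound lasts longer), compound 1 (`O=C(O)[C@@H](CO)NC(=O)[C@H]1C[C@@H](O)CN1`) gives > 12 h as a limit of the assay. Compound 2 (`O=C(O)[C@@H](CO)NC(=O)[C@H]1C[C@H](O)CN1`) gives > 12 h as a limit too. Compound 3 (`O=C(O)[C@H](CO)NC(=O)[C@H]1C[C@@H](O)CN1`) stands at > 12 h as a limit as well. The change to compound 4 (`O=C(O)[C@H](CO)NC(=O)[C@@H]1C[C@H](O)CN1`) is the two compounds have the same atoms and bonds and differ only in configuration as drawn: 2 of 3 stereo elements differ; a stereocentre at a saturated ring carbon is drawn R in compound 3 and S in compound 4; a stereocentre at a saturated ring carbon is drawn R in compound 3 and S in compound 4 and nothing leaves or enters. The measured steps are configuration changes too, and none has a readable size: (a step that the two limits leave unreadable from compound 1 to compound 2), (a step that the two limits leave unreadable from compound 1 to compound 3) and (a step that the two limits leave unreadable from compound 2 to compound 3). All three compounds share (the limit of > 12 h in this assay, at which 3 of the 3 values shown sit). The last of these steps also alters two stereo elements, so the expected change is (a step that the limit leaves unreadable from compound 3 to compound 4) with no direction and none beyond the scatter. For compound 4 the estimated half-life is 14 h with an expected range from 8 h to 24 h and a limit reading is likely.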

Compound 4, half-life: > 12 h
Compound 4: no number, only a limit; the forecaster's own chance of this, stated with the estimate: 85%; the middle value is on the limit's open side.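

Among the compounds shown here, no step from compound 1, compound 2 or compound 3 to compound 4 can be read, because all the values shown are limits: the limit of > 12 h in this assay, at which 4 of the 4 values shown sit. The compounds shown leave open whether configuration alters the half-life in this assay at all.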